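This account rests on a few compounds, and the source may have more. Where it says the series, first, only, none or still open, it means among the compounds named here.

Compound 1 `CCOC(=O)c1oc2ccc(N(Cc3ccccc3)S(=O)(=O)c3ccc(Cl)cc3)cc2c1C` carries an ethyl ester on the shared core and a chloro on its sulfonyl ring. In a functional assay on HCT-116 cells (Homo sapiens) for inhibition, read by MTT assay, with a stated time of 72 h (a higher number here means a weaker inhibitor, a lower number a stronger inhibitor), compound 1 gives 4860 nM. Compound 2 `CCOC(=O)c1oc2ccc(N(Cc3ccccc3)S(=O)(=O)c3ccccc3)cc2c1C` lacks that chloro. In this assay compound 2 reaches only > 40000 nM, which is a limit of the assay rather than a number. The change chloro in place of hydrogen on an aromatic carbon thus gives an at least 8.2-fold lower number from compound 2 to compound 1 (0.91 log units; beyond the scatter), and the step is bounded on one side only because compound 2 sits at the limit of > 40000 nM in this assay, at which 1 of the 3 values shown sits.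

Compound 3 `Cc1c(C(=O)NCCCn2ccnc2)oc2ccc(N(Cc3ccccc3)S(=O)(=O)c3ccc(Cl)cc3)cc12` keeps the chloro on the sulfonyl ring but replaces the ethoxy of the ester with a (3-(1H-imidazol-1-yl)propyl)amino group. In this assay compound 3 gives 17100 nM, so a 3.5-fold higher number from compound 1 to compound 3 (0.55 log units; beyond the scatter). The difference between the cores of compound 2 and compound 3 is not broken down here.

Compound 4 `Cc1c(C(=O)NCCCn2ccnc2)oc2ccc(N(Cc3ccc(Cl)cc3)S(=O)(=O)c3ccc(Cl)cc3)cc12` has not yet been measured. It differs from compound 3 by chloro in place of hydrogen on an aromatic carbon. The place reads the same as for the earlier chloro, but cut one bond further out the earlier change read phenylsulfonyl to (4-chlorophenyl)sulfonyl, whereas this one reads benzyl to 4-chlorobenzyl, so it is the same kind of change on a differently named ring. Since the earlier chloro gave an at least 8.2-fold lower number from compound 2 to compound 1 (0.91 log units; beyond the scatter) only as a bound, and the ring here is another one, a smaller gain is expected, namely a 2.4-fold lower number from compound 3 to compound 4 (0.39 log units; beyond the scatter). Compound 4 is therefore estimated at 7000 nM, expected to fall between 2500 nM and 20000 nM.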

Compound 4, half-maximal inhibitory concentration: 2430 nM
Compound 4: the middle estimate sits 2.9-fold (0.46 log units) above what was measured, outside the stated range (below it).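

In this assay, chloro in place of hydrogen on the benzyl ring gives a 7.0-fold lower number from compound 3 to compound 4 (0.85 log units; beyond the scatter), which is a second case of this small change lowering the number, this time on a different ring from the sulfonyl ring of the earlier case. Two cases show that the direction held on both cores, but they do not show that the size of the step carries over, or that the same gain would appear on any other core in this series: the same change on two cores in this assay, an at least 8.2-fold lower number (0.91 log units; beyond the scatter) from compound 2 to compound 1 and a 7.0-fold lower number (0.85 log units; beyond the scatter) from compound 3 to compound 4; the limit leaves it open whether they differ Compound 2 stands at > 40000 nM, which is a limit of the assay and not a number.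

The compounds shown leave open whether another group in the place of this chloro, such as fluoro, methyl or methoxy, would lower the number as well, and whether 4-chlorobenzyl would give a similar step on the ethyl ester core of compound 1. They also leave open how an amine, a carboxylic acid or a longer chain would fare in place of the ethoxy of the ester or the (3-(1H-imidazol-1-yl)propyl)amino group of the amide.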